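A Further Trifluoromethyl Group at the Assay Limit

This account rests on a few compounds, and the source may have more. Where it says the series, first, only, none or still open, it means among the compounds named here.

The series is read in a functional assay on NALM-6 cells (Homo sapiens) for cytotoxicity, with a stated time of 72 h; on this read-out higher numbers stand for an effect only at larger amounts of compound and lower numbers for an effect already at smaller amounts. There, compound 1 (`C=C[C@@](C)(/C=C/c1ccc(Nc2ccccc2)cc1)CCC=C(C)C`) gives > 43400 nM, which is a limit and not a number. Compound 2 (`C=C[C@@](C)(/C=C/c1ccc(Nc2cccc(C(F)(F)F)c2)cc1)CCC=C(C)C`) gives > 43400 nM, which is likewise only a limit, so its standing is known only as far as that bound.

Compound 3 (`C=C[C@@](C)(/C=C/c1ccc(Nc2cc(C(F)(F)F)cc(C(F)(F)F)c2)cc1)CCC=C(C)C`) follows from compound 2 by one further change, trifluoromethyl in place of hydrogen on an aromatic carbon, meta to a trifluoromethyl group. For the measured compounds named here, the only measured step that bears on it is the same kind of replacement, a step that the two limits leave unreadable from compound 1 to compound 2. Its size cannot be taken from the data, and the whole record amounts to the limit of > 43400 nM in this assay, at which 2 of the 2 values shown sit. No measured change therefore points in either direction, and no step beyond the scatter is expected in this assay.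

The estimated outcome is a step that the limit leaves unreadable from compound 2 to compound 3, and a further limit is the most likely report. Compound 3 is estimated at 45000 nM, with an expected range from 15000 nM to 90000 nM.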

Compound 3, half-maximal effective concentration: > 43400 nM
Compound 3 was reported as a limit; the forecaster's own chance of this, stated with the estimate: 80%; the middle value does not contradict the limit.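

In this assay compound 3 gives > 43400 nM, which is again a limit and not a number. For the compounds shown here, no step can therefore be read between compound 2 and compound 3. The compounds shown leave open where the values of compound 1, compound 2 and compound 3 truly lie, and whether trifluoromethyl changes them at all, the whole record being this: the limit of > 43400 nM in this assay, at which 3 of the 3 values shown sit.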